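Swapping Bromo for Ethoxy: An Expected Loss of Binding

The source may hold more compounds than are shown below. What is called first, only, known or untested is meant among the compounds shown, and "the series" means these compounds.

Three measured compounds share one core and differ only in the group on the aromatic ring. Compound 1 `Cc1cccc(C)c1OC(C)C1=NCCN1` gives 251 nM in an assay on CHO cells for displacement of a labelled ligand from Alpha-2C adrenergic receptor (Homo sapiens); a higher number here means a weaker inhibitor, a lower number a stronger inhibitor. Compound 2 `CC(Oc1ccccc1Br)C1=NCCN1` gives 282 nM in this assay, and compound 3 `COc1ccccc1OC(C)C1=NCCN1` gives 832 nM in this assay. On these numbers compound 2 stands second highest of the three: it sits within the scatter of compound 1 and well apart from compound 3.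

The unmeasured compound 4 `CCOc1ccccc1OC(C)C1=NCCN1` differs from compound 2 in one place: ethoxy in place of bromo on an aromatic carbon

For the measured compounds named here, one measured step bears on this change: a 3.0-fold higher number from compound 2 to compound 3 (0.47 log units; beyond the scatter), where methoxy replaced bromo on an aromatic carbon. Ethoxy resembles methoxy, and a weakening of similar size, perhaps slightly larger, is expected here. Because a 3.0-fold higher number from compound 2 to compound 3 (0.47 log units; beyond the scatter) already showed that direction, compound 4 is expected to give 1000 nM in this assay, with a likely range from 400 nM to 2500 nM. The expected step is a 3.5-fold higher number from compound 2 to compound 4 (0.55 log units; beyond the scatter).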

Compound 4, inhibition constant: 759 nM
The estimate for compound 4 lay 1.3-fold (0.12 log units) above the measured number, within the range that was stated.
By their numbers in this assay, from the lowest: compounds 1 and 2 (each within the scatter of the next); then compounds 4 and 3 (each within the scatter of the next).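

In this assay, ethoxy in place of bromo gives a 2.7-fold higher number from compound 2 to compound 4 (0.43 log units; beyond the scatter), and methoxy in place of bromo gave a 3.0-fold higher number from compound 2 to compound 3 (0.47 log units; beyond the scatter), so both of these oxygen-linked groups read beyond the scatter from bromo at this ring position. Adding one methyl to the methoxy group to make ethoxy gives a 1.1-fold lower number from compound 3 to compound 4 (0.04 log units; within the scatter), which means that across compound 3 and compound 4 the extra chain carbon leaves no readable mark, and the shift travels with the swap away from bromo rather than with the chain length. The data at hand offer no explanation for this shift.

As far as these compounds go, whether a longer chain such as propoxy would still read level with ethoxy remains open. So does whether an amine or a nitrile at this same place would read closer to bromo or closer to the two oxygen-linked groups.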